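Naphthalen-1-yl to 2,6-Dimethylphenyl on a Second Core

This account rests on a few compounds, and the source may have more. Where it says the series, first, only, none or still open, it means among the compounds named here.

Of the compounds shown here, three sharing one core have been tested in an assay on isolated protein for inhibition of serine/threonine-protein kinase PLK1 (Homo sapiens), read by radiometric assay and 33P incorporation, with a stated time of 40 min, tested at 20 uM, in the presence of a further agent that is not named here; on this read-out lower numbers stand for less inhibition and higher numbers for more inhibition at the one concentration tested (going by the name of the read-out). Compound 1 `CCNc1cc(-c2ccc(NC(=O)Nc3cccc4ccccc34)cc2C)ccn1` gives 35.3%. Compound 2 `CCNc1cc(-c2ccc(NC(=O)Nc3c(C)cccc3C)cc2C)ccn1` gives 42.1%. Compound 3 `CCNc1cc(-c2ccc(NC(=O)Nc3cccc4ccccc34)cc2C(F)(F)F)ccn1` gives 54.1%, the highest of the three. Compound 2 differs from compound 1 by 2,6-dimethylphenyl in place of naphthalen-1-yl on an amide-type nitrogen, and that change made a step of a number 6.8 percentage points higher from compound 1 to compound 2 (within the scatter). Compound 3 differs from compound 1 by trifluoromethyl in place of methyl on an aromatic carbon, which made a step of a number 18.8 percentage points higher from compound 1 to compound 3 (beyond the scatter).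

Compound 4 `CCNc1cc(-c2ccc(NC(=O)Nc3c(C)cccc3C)cc2C(F)(F)F)ccn1` has not yet been measured. It differs from compound 3 by 2,6-dimethylphenyl in place of naphthalen-1-yl on an amide-type nitrogen, the same change that separates compound 1 from compound 2, here made on the core of compound 3 instead of the core of compound 1. Since that earlier change gave a number 6.8 percentage points higher from compound 1 to compound 2 (within the scatter), a step of similar modest size is expected here, namely a number 4.9 percentage points higher from compound 3 to compound 4 (within the scatter). This expectation rests on a single earlier example, so the range is kept wide. Compound 4 is therefore estimated to give 59%, somewhere between 45% and 72%.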

Compound 4, a percentage reported as inhibition, at one concentration (the size of the read-out at that concentration, not a potency): 59.2%
Beside the measured number, compound 4's estimate is 0.2 percentage points below it, and the stated range covers the measured number.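

In this assay, 2,6-dimethylphenyl in place of naphthalen-1-yl on the amide-type nitrogen gave a number 5.1 percentage points higher from compound 3 to compound 4 (within the scatter), and this step matches the one seen on the core of compound 1: the same change on two cores in this assay, a number 6.8 percentage points higher (within the scatter) from compound 1 to compound 2 and a number 5.1 percentage points higher (within the scatter) from compound 3 to compound 4, 1.7 percentage points apart, within the scatter of two such steps. Trifluoromethyl in place of methyl on an aromatic carbon gave a number 17.1 percentage points higher from compound 2 to compound 4 (beyond the scatter), and this change also carried over with a similar step: the same change on two cores in this assay, a number 18.8 percentage points higher (beyond the scatter) from compound 1 to compound 3 and a number 17.1 percentage points higher (beyond the scatter) from compound 2 to compound 4, 1.7 percentage points apart, within the scatter of two such steps. Across these four compounds, each change therefore behaved much the same on both cores, but each comparison rests on only two steps at one concentration, the naphthalen-1-yl swap stayed within the scatter both times, and none of this shows why the steps match or how the effects seen at this one concentration would carry over to other concentrations.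

The compounds shown leave open whether such steps would also hold for a plain phenyl or a cyclohexyl on the amide-type nitrogen, or for a nitrile or chlorine in place of the trifluoromethyl. They also leave open what a longer chain in place of the ethyl group would do.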